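The source may hold more compounds than are shown below. What is called first, only, known or untested is meant among the compounds shown, and "the series" means these compounds.

Compound 1 `Cc1ccc(/C=C/C=C2\CCC=CC2=O)cc1`: 5800 nM
Compound 2 `O=C1C=CCC/C1=C\C=C\c1ccc([N+](=O)[O-])cc1`: 4500 nM

In a functional assay on Bel7402/5-FU cells (Homo sapiens) for cytotoxicity, read by MTT assay, with a stated time of 72 h (a lower number here means a stronger inhibitor, a higher number a weaker inhibitor), compound 2 stands at the lower of the two numbers, but its gap to compound 1, a 1.3-fold lower number from compound 1 to compound 2 (0.11 log units; within the scatter), lies within the scatter of repeated measurements. Compound 3 `CN(C)c1ccc(/C=C/C=C2\CCC=CC2=O)cc1` differs from compound 2 in one place: dimethylamino in place of nitro on an aromatic carbon. Within the data shown here, the only measured step that bears on a change at this position is a 1.3-fold lower number from compound 1 to compound 2 (0.11 log units; within the scatter), and it was within the scatter. On that basis no step beyond the scatter is expected in this assay; the expected step is a 1.1-fold higher number from compound 2 to compound 3 (0.05 log units; within the scatter). Compound 3 is estimated at 5000 nM, with a range from 2500 nM to 10000 nM.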

Compound 3, half-maximal inhibitory concentration: 1000 nM
Compound 3: middle estimate off by 5.0-fold (0.70 log units), on the high side, outside the stated range (below it).
By their numbers in this assay, from the lowest: compound 3; then compounds 2 and 1 (each within the scatter of the next).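

In this assay this aromatic position now proves sensitive to the group it carries: there is a 4.5-fold lower number from compound 2 to compound 3 (0.65 log units; beyond the scatter) and a 5.8-fold lower number from compound 1 to compound 3 (0.76 log units; beyond the scatter). Both steps lie beyond the scatter, though both are modest, whereas nitro in place of methyl gave no step beyond it. Dimethylamino therefore stands apart from both earlier groups, which the first pair could not reveal.

From the compounds shown here alone, whether a smaller amine, a methoxy group or a carboxylic acid at this position would match dimethylamino remains open. Nothing available explains the difference.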